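A few compounds are considered here, and "the series" means these few. Any claim that something is new, unique, unknown or untested is made for them only; others in the source may bear on it.

In an ADME assay, at pH 3 (a higher number here means that the compound lasts longer, a lower number that the compound disappears faster), compound 1 (`COc1ccnc(C[S+]([O-])c2nc3cc(OC(F)F)ccc3[nH]2)c1C`) gives 0.0833 h and compound 2 (`COc1ccnc(C[S+]([O-])c2nc3cc(OC(F)(F)C(F)F)ccc3[nH]2)c1OC`) gives 0.3 h as the higher of the two numbers, with the gap beyond the scatter. Compound 3 (`COc1ccnc(C[S+]([O-])c2nc3cc(OC(F)(F)C(F)F)ccc3[nH]2)c1C`) has methyl in place of methoxy on an aromatic carbon relative to compound 2 (methyl in place of methoxy on an aromatic carbon). For the measured compounds named here, no measured pair isolates this change. Compound 1 carries the same methyl, though it differs elsewhere too, and gives 0.0833 h so a modest fall in this assay is expected, slightly beyond the scatter. The expected change is a 2.3-fold lower number from compound 2 to compound 3 (0.36 log units; beyond the scatter) on this reading. Compound 3 is estimated at 0.13 h with a range from 0.07 h to 0.25 h as the likely span.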

Compound 3, half-life: 0.0833 h
Compound 3: the middle estimate sits 1.6-fold (0.19 log units) above what was measured; low and high end bracket the measured number.
By their numbers in this assay, from the lowest: compounds 1 and 3 (each within the scatter of the next); then compound 2.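

In this assay, for the compounds shown here, methyl in place of methoxy on the aromatic carbon two atoms from the ring nitrogen gives a 3.6-fold lower number from compound 2 to compound 3 (0.56 log units; beyond the scatter) as the first isolated reading of this change, so at this position the methoxy of compound 2 is tied to the longer half-life. Difluoromethyl in place of hydrogen on the saturated chain carbon gives no change at the digits printed from compound 1 to compound 3 (within the scatter) with methyl held at that position. Nothing on hand gives a cause for either step.

Going by these compounds, whether ethoxy or an amine at this position would lengthen the half-life further remains open. Also open, on these data alone, is how methoxy at this position behaves with the shorter chain of compound 1.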